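Methyl substitution on the benzamide ring of the chromane-type series

The compounds below may be only part of what the source reports. "The series", "measured", "known", "first", "only" and "open" are said of these compounds alone.

Measured compounds in a functional assay on CHO cells for antagonist activity at prostaglandin D2 receptor (Mus musculus), read by cAMP accumulation and immunoassay, with a stated time of 10 min; on this read-out higher numbers stand for weaker inhibition and lower numbers for stronger inhibition:
- compound 1 `Cc1cc(OC[C@@H]2CN(C)c3ccccc3O2)cc(C)c1C(=O)Nc1cccc(CC(=O)O)c1`: 3.5 nM
- compound 2 `Cc1ccc(CC(=O)O)cc1NC(=O)c1c(C)cc(OC[C@@H]2CN(C)c3ccccc3O2)cc1C`: 4.8 nM
- compound 3 `Cc1cc(OC[C@@H]2CN(C)c3ccccc3O2)ccc1C(=O)Nc1cc(CC(=O)O)ccc1Cl`: "not determined" (no result reported)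

Compound 3 stands without a number in this assay, so its position relative to compound 1 and compound 2 cannot be read from the data. Compound 4 `Cc1cc(OC[C@@H]2CN(C)c3ccccc3O2)cc(C)c1C(=O)Nc1cc(CC(=O)O)ccc1Cl` differs from compound 3 by methyl in place of hydrogen on an aromatic carbon. For the measured compounds named here, the only measured step of the same kind is a 1.4-fold higher number from compound 1 to compound 2 (0.14 log units; within the scatter), a methyl added at another position on the acid-bearing ring, which stayed within the scatter. On that basis no shift beyond the scatter is expected in this assay from adding the methyl, and compound 4 is expected to sit near the values of compound 1 and compound 2. Compound 4 is estimated at 5 nM, with a range of 1.5 nM to 20 nM.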

Compound 4, half-maximal inhibitory concentration: 7.6 nM
The estimate for compound 4 lay 1.5-fold (0.18 log units) below the measured number; the measured number falls inside the stated range.
By their numbers in this assay, from the lowest: compounds 1, 2 and 4 (each within the scatter of the next, the first and the last beyond it).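

In this assay, chloro and methyl on this aromatic carbon are not separated (a 1.6-fold higher number from compound 2 to compound 4 (0.20 log units; within the scatter)). Chloro in place of hydrogen gives the first step in the series beyond the scatter, though a modest one (a 2.2-fold higher number from compound 1 to compound 4 (0.34 log units; beyond the scatter)), whereas methyl at the same carbon stayed within it. No evidence on the cause of this small difference is available.

The step from compound 3 to compound 4 cannot be read, as compound 3 has no number. From the compounds shown here alone, whether fluoro, methoxy or an amine on this carbon would keep the number in this range remains open.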